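Methyl to cyclopropyl: what happens to plasma exposure?

The compounds below may be only part of what the source reports. "The series", "measured", "known", "first", "only" and "open" are said of these compounds alone.

Compound 1 `CC[C@@H](Nc1c(Nc2cccc(C(=O)N(C)C)c2O)c(=O)c1=O)c1ccc(C)s1`: 5830 ng.h/mL
Compound 2 `Cc1ccc([C@@H](C)Nc2c(Nc3cccc(C(=O)N(C)C)c3O)c(=O)c2=O)o1`: 13000 ng.h/mL

In an ADME assay on the whole organism (plasma) for pharmacokinetics, with Rattus norvegicus as the target, with a stated time of 6 h, at a dose of 10 mg/kg by the oral route (a higher number here means more compound in the circulation at the dose given, a lower number less compound in the circulation), compound 2 stands higher of the two measured compounds, at 13000 ng.h/mL. Compound 3 `Cc1ccc([C@H](Nc2c(Nc3cccc(C(=O)N(C)C)c3O)c(=O)c2=O)C2CC2)o1` differs from it in one place: cyclopropyl in place of methyl on a saturated chain carbon bound to an aromatic carbon and a nitrogen on an aromatic ring. Within the data shown here, the only measured step, a 2.2-fold higher number from compound 1 to compound 2 (0.35 log units; beyond the scatter), is modest, and it alters the ring group and the chain together, so it bears only loosely on this change. A small fall, probably within the usual scatter, is therefore expected in this assay: the estimated change is a 1.6-fold lower number from compound 2 to compound 3 (0.21 log units; within the scatter). For compound 3 the expected value is 8000 ng.h/mL, with an estimated range of 3000 ng.h/mL to 18000 ng.h/mL.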

Compound 3, area under the concentration-time curve: 573 ng.h/mL
Compound 3: middle estimate off by 14-fold (1.14 log units), on the high side; the measured number lies below the stated range.
By their numbers in this assay, from the lowest: compound 3; then compound 1; then compound 2.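

On this saturated chain carbon, cyclopropyl in place of methyl is no minor swap: it gives a 23-fold lower number from compound 2 to compound 3 (1.36 log units; beyond the scatter) in this assay and shows that this position matters far more than the earlier pair could reveal. The 1-(5-methylthiophen-2-yl)propyl group also outperforms cyclopropyl(5-methylfuran-2-yl)methyl, with a 10-fold lower number from compound 1 to compound 3 (1.01 log units; beyond the scatter) as the step between them. Nothing available explains this fall.

Still open, as far as these compounds go, is whether an isopropyl or a methoxymethyl group on this carbon would bring a similar fall, or whether it is particular to cyclopropyl.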